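The source may hold more compounds than are shown below. What is called first, only, known or untested is meant among the compounds shown, and "the series" means these compounds.

In an ADME assay on L1210/0 cells (Mus musculus) for cytotoxicity, with a stated time of 48 h (on this read-out higher numbers stand for weaker inhibition and lower numbers for stronger inhibition), three compounds built on one shared core have been tested so far. Compound 1 `N#Cc1cn([C@H]2C[C@H](O)[C@@H](CO)O2)c(=O)[nH]c1=O` gives only a limit of the assay, > 200000 nM. Compound 2 `C[S+]([O-])c1cn([C@H]2C[C@H](O)[C@@H](CO)O2)c(=O)[nH]c1=O` also gives only a limit, > 200000 nM. Compound 3 `CCCC#Cc1cn([C@H]2C[C@H](O)[C@@H](CO)O2)c(=O)[nH]c1=O`, which carries pent-1-yn-1-yl, likewise gives only a limit, > 200000 nM. The whole set therefore stands at the limit of > 200000 nM in this assay, at which 3 of the 3 values shown sit, and compound 3 has no number of its own.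

Compound 4 `CCC#Cc1cn([C@H]2C[C@H](O)[C@@H](CO)O2)c(=O)[nH]c1=O` differs from compound 3 by hydrogen in place of methyl on a saturated chain carbon, two bonds along the chain from a triple-bonded carbon, which turns pent-1-yn-1-yl into but-1-yn-1-yl.

The closest measured change is a step that the two limits leave unreadable from compound 1 to compound 3, and the other two are a step that the two limits leave unreadable from compound 1 to compound 2 and a step that the two limits leave unreadable from compound 2 to compound 3. None of these has a readable size, so they offer no direction, and no step beyond the scatter is expected. The expected result is a number no higher from compound 3 to compound 4 (the limit leaves the size open), most likely reported as another limit. Compound 4 is estimated at 200000 nM, with an expected range from 60000 nM to 400000 nM.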

Compound 4, half-maximal inhibitory concentration: > 200000 nM
Compound 4: only a limit was reported; the forecaster's own chance of this, stated with the estimate: 75%; the middle value lies on the limit itself.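

The steps from compound 1, compound 2 and compound 3 to compound 4 cannot be read, as compound 4 too gives only a limit: the limit of > 200000 nM in this assay, at which 4 of the 4 values shown sit.

The compounds shown leave open whether any group on the shared core gives an actual number in this assay, and so how these groups compare.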